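Amino-substituted core series: the step from propyl to benzyl

The source may hold more compounds than are shown below. What is called first, only, known or untested is meant among the compounds shown, and "the series" means these compounds.

Compounds measured in a functional assay on LN-229 cells (Homo sapiens) for inhibition, read by MTT assay, with a stated time of 72 h (on this read-out higher numbers stand for weaker inhibition and lower numbers for stronger inhibition), so far:
compound 1 `CCCNc1cc(-c2ccccc2)nc2cc(OC)cc(OC)c12` gives 1820 nM
compound 2 `CCCCNc1cc(-c2ccccc2)nc2cc(OC)cc(OC)c12` gives 3920 nM
compound 3 `COc1cc(OC)c2c(-n3ccnc3)cc(-c3ccccc3)nc2c1` gives 55300 nM

Compound 2 stands second highest of the three numbers; its nearest neighbour is compound 1, lower by a 2.2-fold higher number from compound 1 to compound 2 (0.33 log units; beyond the scatter), and the furthest is compound 3, higher by a 14-fold higher number from compound 2 to compound 3 (1.15 log units; beyond the scatter). Compound 3 also stands far from compound 1, by a 30-fold higher number from compound 1 to compound 3 (1.48 log units; beyond the scatter). Both large steps concern the exchange of the chain amine for 1H-imidazol-1-yl; neither introduces a phenyl on the chain.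

Compound 4 `COc1cc(OC)c2c(NCc3ccccc3)cc(-c3ccccc3)nc2c1` is not yet measured. Its difference from compound 2 is phenyl in place of propyl on a saturated chain carbon bound to a nitrogen on an aromatic ring, that is, butylamino becomes benzylamino. For the measured compounds named here, the only step that bears on a change along this chain is the one from compound 1 to compound 2, a modest loss on lengthening the chain by one carbon. Going by the values given here, no measured step replaces a chain carbon with a ring, so the size of the step from compound 2 to compound 4 in this assay is uncertain. A change of modest size in the direction of a higher number is expected for compound 4, a 1.3-fold higher number from compound 2 to compound 4 (0.11 log units; within the scatter), on the ground that chain extension in the step from compound 1 to compound 2 raised the number by a 2.2-fold higher number from compound 1 to compound 2 (0.33 log units; beyond the scatter). The estimate for compound 4 is 5000 nM, with a range from 1500 nM to 16000 nM.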

Compound 4, half-maximal inhibitory concentration: 7150 nM
Compound 4: the middle estimate sits 1.4-fold (0.16 log units) below what was measured; measured number inside the range.
By their numbers in this assay, from the lowest: compound 1; then compounds 2 and 4 (each within the scatter of the next); then compound 3.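

In this assay, a phenyl on the saturated chain carbon bound to a nitrogen on an aromatic ring gives a number that cannot be separated from that of the butyl chain (a 1.8-fold higher number from compound 2 to compound 4 (0.26 log units; within the scatter)), so this position accepts a six-membered aromatic ring in place of propyl without a change beyond the scatter. The benzylamino group still separates from propylamino (a 3.9-fold higher number from compound 1 to compound 4 (0.59 log units; beyond the scatter)) and from 1H-imidazol-1-yl (a 7.7-fold lower number from compound 3 to compound 4 (0.89 log units; beyond the scatter)), which shows that a ring carried on the chain amine does not reproduce the weak inhibition of compound 3, while the propylamino compound 1 keeps the lowest number of the set. Nothing available explains these differences.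

Among the compounds shown, the phenyl ring of the benzylamino group carries no substituent, so the effect of a methoxy group, a chlorine or a carboxylic acid on that ring remains unknown. Also open, on these data alone, are the two-carbon phenethylamino chain, which would place the phenyl further from the amine nitrogen, and a saturated cyclohexylmethylamino group, which would show whether the aromatic ring itself matters at this position.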